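The source may report more compounds than this note shows. Statements on the series, on what has been measured and on what is new or still open speak of the compounds shown alone.

Compound 2 `CC1(C)COC(c2cccc(OC(=O)NC3CCCC3)c2)=N1` is the reference point. In an assay on membranes from cerebellum (strain Wistar) for inhibition of Monoglyceride lipase (Rattus norvegicus), read by HPLC, tested at 100 uM (a higher number here means more inhibition at the concentration tested (going by the name of the read-out), a lower number less inhibition), compound 2 gives 28%, the highest of the three numbers available, although every neighbour sits within the usual scatter of it. Compound 1 `CCCNC(=O)Oc1cccc(-c2nc3ccccc3o2)c1` gives 26% in this assay, and compound 3 `CC1(C)COC(c2cccc(OC(=O)NC3CCCCC3)c2)=N1` gives 20%.

Among the measured compounds shown here, the one step measured so far runs from compound 2 to compound 3, a cyclohexyl in place of a cyclopentyl on an amide-type nitrogen, and in this assay it amounts to a number 8 percentage points lower from compound 2 to compound 3 (within the scatter). Compound 4 `C[C@H]1COC(c2cccc(OC(=O)NC3CCCC3)c2)=N1` differs from compound 2 elsewhere: a group of 6 heavy atoms (4 carbon, 1 nitrogen, 1 oxygen; one five-membered non-aromatic ring with 2 hetero atoms) in place of a group of 7 heavy atoms (5 carbon, 1 nitrogen, 1 oxygen; one five-membered non-aromatic ring with 2 hetero atoms), on an aromatic carbon. For the measured compounds named here, no measured pair changes the group at that aromatic carbon, so the only guidance is indirect: the sole measured step stayed within the scatter, and the three numbers at hand lie close together.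

Compound 4 is therefore expected to show a step of a number 2 percentage points lower from compound 2 to compound 4 (within the scatter) in this assay, that is, none beyond the scatter. The estimate for compound 4 in this assay is 26%, with a range from 12% to 40%.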

Compound 4, a percentage reported as inhibition, at one concentration (the size of the read-out at that concentration, not a potency): 28%
Compound 4: the middle estimate sits 2 percentage points below what was measured; low and high end bracket the measured number.
By their numbers in this assay, from the lowest: compounds 3, 1, 2 and 4 (each within the scatter of the next).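

In this assay, the change on the aromatic carbon, a group of 6 heavy atoms carrying one defined stereocentre in place of a group of 7 heavy atoms, gives no change at the digits printed from compound 2 to compound 4 (within the scatter). Among the compounds shown here, until this pair, the only measured step lay on the amide-type nitrogen; this one shows that at this position, on the six-membered aromatic ring, the two five-membered non-aromatic rings cannot be told apart at the single concentration tested. No accompanying measurement bears on this result.

Going by these compounds, whether the mirror-image form of compound 4 reads the same remains open. So does whether an amine or a carboxylic acid on that aromatic carbon, in place of the five-membered non-aromatic ring, would move the number beyond the scatter.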